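Trifluoromethylphenyl replaces methoxyphenoxy on the shared core

A few compounds are considered here, and "the series" means these few. Any claim that something is new, unique, unknown or untested is made for them only; others in the source may bear on it.

Compound 3 `COc1ccccc1Oc1ccc2c(NCCCNCc3cccc(OC)c3O)ccnc2c1` gives 9.28 in a physicochemical assay for acid dissociation. Compound 2 `COc1cccc(CNCCCNc2ccnc3cc(Oc4ccc(F)cc4)ccc23)c1O` gives 9.28, and compound 1 `COc1cccc(CNCCCNc2ccnc3cc(Cc4cc(C)cc(C)c4)ccc23)c1O` gives 9.47. The step of no change at the digits printed from compound 2 to compound 3 (within the scatter) and the step of a number 0.19 log units lower from compound 1 to compound 3 (within the scatter) both lie within the scatter, as does a number 0.19 log units lower from compound 1 to compound 2 (within the scatter); the three numbers sit together, with compound 3 level with compound 2 at the digits shown. Compound 4 `COc1cccc(CNCCCNc2ccnc3cc(-c4ccc(C(F)(F)F)cc4)ccc23)c1O` differs from compound 3 by 4-(trifluoromethyl)phenyl in place of 2-methoxyphenoxy on an aromatic carbon. Within the data shown here, the steps that bear on this change, a number 0.19 log units lower from compound 1 to compound 3 (within the scatter) and no change at the digits printed from compound 2 to compound 3 (within the scatter), were both within the scatter, so no step beyond the scatter is expected here in this assay, an expected step of a number 0.02 log units higher from compound 3 to compound 4 (within the scatter). Compound 4 is therefore estimated at 9.3, with a range from 8.9 to 9.7.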

Compound 4, acid dissociation constant: 9.47
For compound 4 the middle estimate is 0.17 log units below the measured one, and the stated range covers the measured number.
By their numbers in this assay, from the lowest: compounds 2, 3, 1 and 4 (each within the scatter of the next).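

At this aromatic carbon, 4-(trifluoromethyl)phenyl, with 0 hydrogen-bond acceptors, stays within the scatter of all three earlier compounds in this assay (a number 0.19 log units higher from compound 3 to compound 4 (within the scatter); a number 0.19 log units higher from compound 2 to compound 4 (within the scatter); no change at the digits printed from compound 1 to compound 4 (within the scatter)). The four groups shown here therefore give no step beyond the scatter, whether or not they carry oxygen. No supporting evidence bears on this result. As far as these compounds go, whether an amine or a carboxylic acid at this place would move the number beyond the scatter remains open.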